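The compounds below may be only part of what the source reports. "The series", "measured", "known", "first", "only" and "open" are said of these compounds alone.

So far two compounds have been tested in a functional assay on HCT-8 cells (Homo sapiens) for cytotoxicity, read by MTT assay; a lower number here means a stronger inhibitor, a higher number a weaker inhibitor: compound 1 `C[C@@H]1CC[C@]2(O)O[C@]13C=C(C(C)(C)O)C(=O)[C@H]3[C@@H]2C` and compound 2 `CC1=C[C@H](O)[C@]2(CC1=O)[C@H](C)CC(=O)[C@H]2C(C)C`. Compound 1 gives > 10000 nM, which is a limit of the assay and not a number. Compound 2 gives > 10000 nM, which is likewise a limit. Neither result therefore offers an exact potency, and both end at the same point: the limit of > 10000 nM in this assay, at which 2 of the 2 values shown sit.

The next compound, compound 3 `CC1=C[C@@H](O)[C@@]2(CC1=O)[C@@H](C(C)C)C(=O)C[C@@H]2C`, is built from the same atoms and bonds as compound 2, and the whole change lies in its three-dimensional arrangement: the two compounds have the same atoms and bonds and differ only in configuration as drawn: 3 of 4 stereo elements differ; a stereocentre at a saturated ring carbon is drawn S in compound 2 and R in compound 3; a stereocentre at a saturated ring carbon is drawn S in compound 2 and R in compound 3; a stereocentre at a saturated ring carbon is drawn R in compound 2 and S in compound 3. Nothing leaves and nothing enters. Two stereocentres at saturated ring carbons are drawn S in compound 2 and R in compound 3, and a third is drawn R in compound 2 and S in compound 3.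

Among the measured compounds shown here, no measured step shows what such a change does in this assay. Compound 3 is expected to stay weak, with no step beyond the scatter, because compound 2 gives > 10000 nM. The estimated change is small: a step that the limit leaves unreadable from compound 2 to compound 3. For compound 3 the expected value is 15000 nM, with an estimated range of 7000 nM to 40000 nM.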

Compound 3, half-maximal inhibitory concentration: > 10000 nM
Compound 3: no number, only a limit; the forecaster's own chance of this, stated with the estimate: 85%; the middle value is on the limit's open side.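

Among the compounds shown here, compound 2 and compound 3 both end at a limit of the assay and not at a number, so no step between them can be read in this assay. The compounds shown leave open whether the change in configuration as drawn alters potency at all, and how any of the three compounds would compare beyond that limit.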